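Nitro in place of cyano on compound 3

This account rests on a few compounds, and the source may have more. Where it says the series, first, only, none or still open, it means among the compounds named here.

compound 1 `COc1cc2nc(Nc3ccc(C#N)cc3)nc(Nc3c(Cl)cc(/C=C/C#N)cc3Cl)c2cc1OC`: 9920 nM
compound 2 `COc1cc2nc(Nc3ccc(C#N)cc3)nc(Nc3c(C)cc(/C=C/C#N)cc3F)c2cc1OC`: > 52000 nM (a limit)
compound 3 `COc1cc2nc(SCC(=O)Nc3ccc(C#N)cc3)nc(Nc3c(C)cc(/C=C/C#N)cc3C)c2cc1OC`: > 227000 nM (a limit)

These readings come from an ADME assay on MT4 cells (Homo sapiens) for cytotoxicity, read by MTT assay, with a stated time of 5 days; on this read-out higher numbers stand for lower toxicity in this test and lower numbers for higher toxicity in this test. Compound 3 stands at the limit of > 227000 nM in this assay, at which 1 of the 3 values shown sits, so its reading is a limit and not a number. Compound 4 `COc1cc2nc(SCC(=O)Nc3ccc([N+](=O)[O-])cc3)nc(Nc3c(C)cc(/C=C/C#N)cc3C)c2cc1OC` carries nitro in place of cyano on an aromatic carbon, para to a large group: nitro in place of cyano on an aromatic carbon. Among the measured compounds shown here, the one measured step, an at least 5.2-fold higher number from compound 1 to compound 2 (0.71 log units; beyond the scatter), lies elsewhere in the structure and leaves the cyano untouched, so it gives only a loose guide to size. For the measured compounds named here, no measured step makes this exchange. Any readable change is expected to be downward because compound 3 is only a limit at > 227000 nM. The estimated change is an at least 1.5-fold lower number from compound 3 to compound 4 (0.17 log units; that floor lies within the scatter). Compound 4 is expected at 150000 nM, with an estimated range from 30000 nM to 230000 nM.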

Compound 4, half-maximal cytotoxic concentration: > 219000 nM
Compound 4 gave a limit, no number (the forecaster's own chance of this, stated with the estimate: 60%); at least 1.4-fold (0.16 log units) between middle value and limit.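

In this assay compound 3 gives a limit, > 227000 nM. Compound 4 also gives a limit, > 219000 nM. Among the compounds shown here, no step between compound 3 and compound 4 can be read. The compounds shown leave open whether nitro in place of cyano changes the reading at all, and in which direction.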